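From butyl to (cyclopropylmethyl)amino on a carbonyl carbon

A few compounds are considered here, and "the series" means these few. Any claim that something is new, unique, unknown or untested is made for them only; others in the source may bear on it.

Values measured in an ADME assay on HEK-293T cells (Homo sapiens) for cytotoxicity, read by luminescence, with a stated time of 24 h (a higher number here means that more compound is tolerated, a lower number that less compound is tolerated), are as follows.

- Compound 1 `CCOC(=O)C1CCN(C(=O)c2cc3sccc3n2Cc2ccc(OC)cc2)CC1` gives 39000 nM
- Compound 2 `COc1ccc(Cn2c(C(=O)N3CCC(C(=O)NC(C)c4ccccc4)CC3)cc3sccc32)cc1` gives > 100000 nM (a limit of the assay, not a number)
- Compound 3 `CCCCC(=O)C1CCN(C(=O)c2cc3sccc3n2Cc2ccc(OC)cc2)CC1` gives 38900 nM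

Going by the values given here, compound 3, at 38900 nM, sits level with compound 1, the only other compound with a numerical value. The measured step between them is a 1.0-fold lower number from compound 1 to compound 3 (0.00 log units; within the scatter), so exchanging ethoxy for butyl left the number unmoved.

Compound 4 `COc1ccc(Cn2c(C(=O)N3CCC(C(=O)NCC4CC4)CC3)cc3sccc32)cc1` carries (cyclopropylmethyl)amino in place of butyl on a carbonyl carbon, the place where that carbon's other neighbour is a saturated ring carbon.

Among the compounds with values here, the closest precedent is compound 2, which also has an amino group on this carbonyl carbon. Within the data shown here, two steps bear on the change: an at least 2.5-fold higher number from compound 1 to compound 2 (0.40 log units; beyond the scatter) and an at least 2.5-fold lower number from compound 2 to compound 3 (0.41 log units; beyond the scatter). On these data alone, both rest on (the limit of > 100000 nM in this assay, at which 1 of the 3 values shown sits), so their true size remains open. Compound 2 is a single example, and its (1-phenylethyl)amino group differs from the group in compound 4, so the precedent carries over only in part.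

A modest rise is therefore expected, probably beyond the scatter, with the assay limit possibly reached. The expected change is a 2.1-fold higher number from compound 3 to compound 4 (0.31 log units; beyond the scatter) in size. For compound 4 the estimate is 80000 nM, with an expected range of 38000 nM to 100000 nM.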

Compound 4, half-maximal cytotoxic concentration: 24600 nM
Estimate against measurement, compound 4: 3.3-fold (0.51 log units) above; the whole stated range lies above it.
By their numbers in this assay, from the lowest: compounds 4, 3 and 1 (each within the scatter of the next). At a limit, above all of these: compound 2.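

In this assay, an amino group on this carbonyl carbon does not by itself set a compound apart: (cyclopropylmethyl)amino gives a 1.6-fold lower number from compound 3 to compound 4 (0.20 log units; within the scatter), and against ethoxy it gives a 1.6-fold lower number from compound 1 to compound 4 (0.20 log units; within the scatter), so these three groups read alike at this place. The separation lies instead between the two amides, where cyclopropylmethyl in place of 1-phenylethyl on the amide-type nitrogen gives an at least 4.0-fold lower number from compound 2 to compound 4 (0.60 log units; beyond the scatter), which ties the high reading of compound 2 to its 1-phenylethyl group and not to the amide as such. Compound 2 gives > 100000 nM, a limit of the assay and not a number, so the true size of that step stays open: the limit of > 100000 nM in this assay, at which 1 of the 4 values shown sits.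

With only two amide groups shown, it remains open whether the phenyl ring or the methyl branch of 1-phenylethyl matters, which benzylamino or a longer unbranched alkylamino group on this carbonyl carbon would help to separate. A carboxylic acid at this place also lies outside the compounds shown, so the reach of the series in this assay beyond neutral groups is unknown.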